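This account rests on a few compounds, and the source may have more. Where it says the series, first, only, none or still open, it means among the compounds named here.

Measured compounds and values:
- compound 1, `CC1c2cc(Cl)ccc2C(=O)N1c1cccnc1`: 123 nM
- compound 2, `CC(=O)N[C@@H]1CCCc2c1cncc2N1C(=O)c2ccc(Cl)cc2[C@H]1C`: 130 nM
- compound 3, `CC(=O)N[C@@H]1CCCc2c1cncc2N1C(=O)c2ccc(Cl)cc2[C@H]1C1CC1`: 100 nM

These three were tested in an assay on cells for inhibition of cytochrome P450 11B2, mitochondrial (Homo sapiens), read by HTRF (on this read-out lower numbers stand for stronger inhibition and higher numbers for weaker inhibition), and their numbers lie close together. Compound 4, `O=C1c2ccc(Cl)cc2C(C2CC2)N1c1cccnc1`, has not yet been measured there.

From compound 2 to compound 3 the change is cyclopropyl in place of methyl on a saturated ring carbon, and it gave a 1.3-fold lower number from compound 2 to compound 3 (0.11 log units; within the scatter). From compound 1 to compound 4 the change is cyclopropyl in place of methyl on a saturated ring carbon. It is the same kind of change, though in compound 2 the ring atom next to the place bears a large group, while in compound 1 it bears a pyridin-3-yl group. The difference between the two cores is not broken down here.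

Because the comparable change gave only a 1.3-fold lower number from compound 2 to compound 3 (0.11 log units; within the scatter), a small step is expected for compound 4 as well: a 1.2-fold lower number from compound 1 to compound 4 (0.09 log units; within the scatter). Compound 4 is therefore estimated at 100 nM, likely between 50 nM and 220 nM.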

Compound 4, half-maximal inhibitory concentration: 161 nM
Compound 4: middle estimate off by 1.6-fold (0.21 log units), on the low side, and the stated range covers the measured number.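

In this assay, cyclopropyl in place of methyl on a saturated ring carbon gave a 1.3-fold higher number from compound 1 to compound 4 (0.12 log units; within the scatter), so on the core of compound 1 this step cannot be told apart from ordinary repeat scatter. Carried from one core to the other, the change stayed small on both, and the two steps cannot be told apart: the same change on two cores in this assay, a 1.3-fold lower number (0.11 log units; within the scatter) from compound 2 to compound 3 and a 1.3-fold higher number (0.12 log units; within the scatter) from compound 1 to compound 4, 1.7-fold (0.23 log units) apart, within the scatter of two such steps. Among the compounds shown here, this shows that the swap was tolerated on these two cores, but it rests on only two pairs and does not show that the change would stay small on any other core.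

The compounds shown leave open what other groups on this saturated ring carbon would do, such as a longer chain, an amine or a carboxylic acid. They also leave open whether any such group would give a step beyond the scatter on either core.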